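This account rests on a few compounds, and the source may have more. Where it says the series, first, only, none or still open, it means among the compounds named here.

Measured so far:
- compound 1 `O=C(/C=C/c1ccc(Br)cc1)NNC(=O)c1ccc2c(c1)OCCO2` gives 259000 nM in an ADME assay on cells (Macrophage) for cytotoxicity, read by MTT assay, with a stated time of 24 h; a lower number here means that less compound is tolerated, a higher number that more compound is tolerated
- compound 2 `O=C(/C=C/c1ccccc1)NNC(=O)c1ccc2c(c1)OCCO2` gives 312000 nM in this assay

Compound 1 holds the lowest of the two numbers in this assay; the nearest is compound 2, and a 1.2-fold higher number from compound 1 to compound 2 (0.08 log units; within the scatter). Compound 3 `Cc1ccccc1/C=C/C(=O)NNC(=O)c1ccc2c(c1)OCCO2` differs from compound 1 by 2-methylphenyl in place of 4-bromophenyl on a double-bonded chain carbon bound to a double-bonded chain carbon. Among the compounds with values here, the only measured step, a 1.2-fold higher number from compound 1 to compound 2 (0.08 log units; within the scatter), touches the same aromatic ring but a different group, so it bears only loosely here; it gives no sign of a shift beyond the scatter. The expected step is therefore a 1.1-fold higher number from compound 1 to compound 3 (0.03 log units; within the scatter) in this assay. Compound 3 is estimated at 280000 nM, expected range 140000 nM to 560000 nM.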

Compound 3, half-maximal cytotoxic concentration: 268000 nM
Compound 3: the middle estimate sits 1.0-fold (0.02 log units) above what was measured; low and high end bracket the measured number.
By their numbers in this assay, from the lowest: compounds 1, 3 and 2 (each within the scatter of the next).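

In this assay, both new steps lie within the scatter: a 1.0-fold higher number from compound 1 to compound 3 (0.01 log units; within the scatter) for 2-methylphenyl in place of 4-bromophenyl on a double-bonded chain carbon bound to a double-bonded chain carbon, and a 1.2-fold lower number from compound 2 to compound 3 (0.07 log units; within the scatter) for methyl in place of hydrogen on an aromatic carbon. Exchanging bromo for methyl on the phenyl group therefore gives no shift beyond the scatter at this place. No evidence bears on this result.

Going by these compounds, whether an amine or a carboxylic acid in place of the 4-bromophenyl would move the number beyond the scatter stays open. Changes to the shared core also remain open.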